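Swapping an aminophenyl for a carboxypyridinyl on the oxazole core

The source may hold more compounds than are shown below. What is called first, only, known or untested is meant among the compounds shown, and "the series" means these compounds.

Of the compounds shown here, three have been tested in an assay (Rattus norvegicus) for inhibition of Fatty-acid amide hydrolase 1 (Homo sapiens) (on this read-out higher numbers stand for weaker inhibition and lower numbers for stronger inhibition), and a fourth awaits its number. Compound 3, with the structure `Nc1ccc(-c2cnc(C(=O)CCCCCCc3ccccc3)o2)cc1`, gives 90 nM in this assay, the second highest of the three numbers. Compound 2, `O=C(CCCCCCc1ccccc1)c1ncc(-c2cccc(C(=O)C(F)(F)F)c2)o1`, gives 16 nM, a lower number than compound 3 by a margin beyond the scatter. Going by the values given here, compound 1, `O=C(CCCCCCc1ccccc1)c1ncc(-c2ccccc2C(=O)C(F)(F)F)o1`, gives 5000 nM, the highest number of the set and the one furthest from compound 3.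

Compound 4, `O=C(CCCCCCc1ccccc1)c1ncc(-c2ncccc2C(=O)O)o1`, is the untested member. It differs from compound 3 in one place: 3-carboxypyridin-2-yl in place of 4-aminophenyl on an aromatic carbon. Among the compounds with values here, no measured pair shows this exact swap, so any expectation rests on the spread of the three numbers already known. Compound 1 shows that a bulky group on the ring attached to the shared core can go with a very high number, while compound 3 shows that a small donor on that ring goes with a moderate one.

The step from compound 3 to compound 4 is expected to be an 11-fold higher number from compound 3 to compound 4 (1.05 log units; beyond the scatter), toward weaker inhibition. Compound 4 is thus estimated at 1000 nM, with a likely range from 200 nM to 5000 nM.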

Compound 4, inhibition constant: > 50 nM
Compound 4 gave a limit, no number; the forecaster's own chance of this, stated with the estimate: 15%; the middle value lies beyond the limit too.
By their numbers in this assay, from the lowest: compound 2; then compound 3; then compound 1.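

In this assay compound 4 gives > 50 nM, which is a limit and not a number, so the step between compound 3 and compound 4 cannot be read. As far as these compounds go, whether 3-carboxypyridin-2-yl in place of 4-aminophenyl gives stronger or weaker inhibition stays open.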